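The source may hold more compounds than are shown below. What is called first, only, known or untested is meant among the compounds shown, and "the series" means these compounds.

Of the compounds shown here, three built on one shared core have so far been tested in a functional assay on Vero cells (Chlorocebus sabaeus) for inhibition; on this read-out higher numbers stand for weaker inhibition and lower numbers for stronger inhibition. Compound 1, `O=C1NC(O)C=CN1[C@@H]1CS[C@@H](CO)O1`, gives > 100000 nM in this assay, and that figure is a limit of the assay rather than a number. Compound 2, `O=c1[nH]c(=O)n([C@@H]2CS[C@@H](CO)O2)cc1Br`, gives > 100000 nM in this assay, again only a limit. Compound 3, `Nc1ncnc2c1ncn2[C@@H]1CS[C@@H](CO)O1`, gives > 100000 nM in this assay, also a limit. Among the measured compounds shown here, compound 2 therefore stands level with the other two: all three sit at the limit of > 100000 nM in this assay, at which 3 of the 3 values shown sit, and there is no measured step between any pair of them to draw on.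

Compound 4, `Cc1cn([C@@H]2CS[C@@H](CO)O2)c(=O)[nH]c1=O`, has not yet been measured. It differs from compound 2 by methyl in place of bromo on an aromatic carbon. For the measured compounds named here, nothing in the measured set shows what exchanging a bromo for a methyl at this place does, since every value so far is a limit. The step from compound 2 is therefore expected to be small, no larger than the scatter, and of no clear direction: a number no higher from compound 2 to compound 4 (the limit leaves the size open) is the expected step. Compound 4 is estimated at 100000 nM, with a range from 20000 nM to 300000 nM, and the likeliest outcome is that the assay again reports only a limit.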

Compound 4, half-maximal inhibitory concentration: > 100000 nM
Compound 4 was reported as a limit; the forecaster's own chance of this, stated with the estimate: 70%; the middle value lies on the limit itself.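

In this assay compound 4 gives > 100000 nM, which is a limit and not a number. Compound 2 also stands only at a limit, so no step can be read for methyl in place of bromo between compound 2 and compound 4. What the compounds shown leave open is whether any compound on the shared core gives a measurable number: the limit of > 100000 nM in this assay, at which 4 of the 4 values shown sit.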